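A few compounds are considered here, and "the series" means these few. Any claim that something is new, unique, unknown or untested is made for them only; others in the source may bear on it.

Values in an ADME assay on K562 cells (Homo sapiens) for antiproliferative activity; on this read-out lower numbers stand for stronger inhibition and higher numbers for weaker inhibition:
- Compound 1 `COc1ccc2nccc(CC[C@H]3CC[C@H](NCc4cc5c(cn4)OCCO5)CC3)c2c1`: 7500 nM
- Compound 2 `COc1ccc2nccc(CC[C@H]3CC[C@H](NCc4ccc5c(c4)OCCO5)CC3)c2c1`: 4200 nM
- Compound 3 `COc1ccc2nccc(CC[C@H]3CC[C@H](NCc4ccc5c(n4)NC(=O)CO5)CC3)c2c1`: not yet measured

Within the data shown here, the two measured values do not separate, and this leaves compound 2 level with its only neighbour: a 1.8-fold lower number from compound 1 to compound 2 (0.25 log units; within the scatter). The next change is a group of 11 heavy atoms (7 carbon, 2 nitrogen, 2 oxygen; one six-membered non-aromatic ring with 2 hetero atoms, one six-membered aromatic ring with 1 hetero atom) in place of a group of 10 heavy atoms (8 carbon, 2 oxygen; one six-membered non-aromatic ring with 2 hetero atoms, one six-membered aromatic ring of carbon only), on a saturated chain carbon bound to an amine nitrogen. Among the measured compounds shown here, the one measured step bearing on it alters the same place and stays small, so no step beyond the scatter is expected in this assay, with only a slight expected lean toward a higher number. With a single step as support, the range stays wide. The expected move is a 1.3-fold higher number from compound 2 to compound 3 (0.12 log units; within the scatter). Compound 3 is estimated at 5500 nM, with an expected range of 2000 nM to 15000 nM.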

Compound 3, half-maximal inhibitory concentration: 12000 nM
Compound 3: the middle estimate sits 2.2-fold (0.34 log units) below what was measured; measured number inside the range.
By their numbers in this assay, from the lowest: compounds 2, 1 and 3 (each within the scatter of the next, the first and the last beyond it).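

In this assay, this position now gives a modest step beyond the scatter: a 2.9-fold higher number from compound 2 to compound 3 (0.46 log units; beyond the scatter), as 2,3-dihydro-1,4-benzodioxin-6-yl gives way to a group with 1 hydrogen-bond donor and 1 double bond outside aromatic rings. The other step stays within the scatter, a 1.6-fold higher number from compound 1 to compound 3 (0.20 log units; within the scatter), so only compound 2 and compound 3 separate. Nothing available accounts for this step.

Which part of the entering group carries the step stays open. So does how a plain phenyl or a morpholine would read on the same saturated chain carbon.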